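A few compounds are considered here, and "the series" means these few. Any claim that something is new, unique, unknown or untested is made for them only; others in the source may bear on it.

Working notes on the series. Compound 3 `O=C(O)C[C@@H]1C[C@H](C(F)(F)F)CN1c1ccc(Oc2ccccc2C(F)(F)F)cc1` gives 1300 nM in a functional assay on cells for agonist activity at Free fatty acid receptor 1 (Mus musculus), read by FLIPR and calcium flux, with a stated time of 100 s; on this read-out higher numbers stand for an effect only at larger amounts of compound and lower numbers for an effect already at smaller amounts. Among the numbers shown in this assay compound 3 stands highest, the nearest being compound 1 `Cc1ccccc1Oc1ccc(N2C[C@@H](C(F)(F)F)C[C@H]2CC(=O)O)cc1`, which in this assay gives 330 nM. Compound 2 `Cc1ccccc1C(=O)c1ccc(N2CCC[C@H]2CC(=O)O)cc1` is reported in this assay only as a limit, > 33000 nM, as the evidence on this point states (the limit of > 33000 nM in this assay, at which 1 of the 3 values shown sits). Going by the values given here, the one measured step that changes the same aromatic position, a 3.9-fold higher number from compound 1 to compound 3 (0.60 log units; beyond the scatter), carries trifluoromethyl in place of methyl.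

Compound 4 `O=C(O)C[C@@H]1C[C@H](C(F)(F)F)CN1c1ccc(Oc2ccccc2OC(F)(F)F)cc1` differs from compound 3 by trifluoromethoxy in place of trifluoromethyl on an aromatic carbon. Among the compounds with values here, no measured step exchanges trifluoromethyl for trifluoromethoxy, so the measured step of a 3.9-fold higher number from compound 1 to compound 3 (0.60 log units; beyond the scatter) bears on it only in that it shows the same position tolerating a change of substituent with a modest move in this assay. On that basis a step of similar or smaller size is expected, in either direction, most likely within the scatter. Compound 4 is therefore expected to give about 1000 nM in this assay, between 330 nM and 3300 nM, which would mean a step of a 1.3-fold lower number from compound 3 to compound 4 (0.11 log units; within the scatter) from compound 3.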

Compound 4, half-maximal effective concentration: 740 nM
Compound 4: the middle estimate sits 1.4-fold (0.13 log units) above what was measured; low and high end bracket the measured number.
By their numbers in this assay, from the lowest: compound 1; then compounds 4 and 3 (each within the scatter of the next). At a limit, above all of these: compound 2.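

In this assay, trifluoromethoxy in place of trifluoromethyl on this aromatic carbon, ortho to a large group, gives a 1.8-fold lower number from compound 3 to compound 4 (0.24 log units; within the scatter), so the added oxygen and its hydrogen-bond acceptor leave no readable difference between these two groups here. Measured against methyl, the new group gives a 2.2-fold higher number from compound 1 to compound 4 (0.35 log units; beyond the scatter), and alongside a 3.9-fold higher number from compound 1 to compound 3 (0.60 log units; beyond the scatter) this places both fluorinated groups beyond the scatter from methyl, with compound 1 holding the lowest number of the three. Nothing at hand bears on the reason for these steps.

Going by these compounds, whether an amine, a nitrile or a chlorine on this aromatic carbon would match methyl or the two fluorinated groups stays open. Also open, on these data alone, is whether the gap between methyl and trifluoromethoxy carries over to a different core.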